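Nitro placement on the bis-arylidene cyclohexanone cytotoxicity series

The source may hold more compounds than are shown below. What is called first, only, known or untested is meant among the compounds shown, and "the series" means these compounds.

Measured so far in a functional assay on MOLT-4 cells (Homo sapiens) for cytotoxicity, with a stated time of 72 h; a higher number here means a weaker inhibitor, a lower number a stronger inhibitor:
compound 1 `COc1cc(/C=C2\CCC/C(=C\c3ccccc3[N+](=O)[O-])C2=O)cc(OC)c1OC` gives 702 nM
compound 2 `O=C1/C(=C/c2ccccc2)CCC/C1=C\c1cccc([N+](=O)[O-])c1` gives 1700 nM
compound 3 `O=C1CCCC/C1=C\c1ccccc1[N+](=O)[O-]` gives 33300 nM

Compound 1 has the lowest number of the three; compound 2 stands beyond the scatter above it, and compound 3, which lacks the trimethoxyphenyl arm, is far weaker still. Compound 4 `COc1cc(/C=C2\CCC/C(=C\c3cccc([N+](=O)[O-])c3)C2=O)cc(OC)c1OC` keeps the core of compound 1 and differs only by 3-nitrophenyl in place of 2-nitrophenyl on a double-bonded chain carbon bound to a double-bonded ring carbon. Going by the values given here, no pair already measured isolates this nitro shift, since compound 2 carries the 3-nitrophenyl on a core without the trimethoxyphenyl arm, so its value cannot be set against compound 1 directly. The step from compound 1 to compound 4 is expected to be small, a 1.3-fold higher number from compound 1 to compound 4 (0.11 log units; within the scatter), leaning toward a slightly higher number. Compound 4 is therefore estimated at 900 nM, within 350 nM to 2500 nM.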

Compound 4, half-maximal inhibitory concentration: 44000 nM
Compound 4: middle estimate off by 49-fold (1.69 log units), on the low side; the whole stated range lies below it.
By their numbers in this assay, from the lowest: compound 1; then compound 2; then compounds 3 and 4 (each within the scatter of the next).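

In this assay, 3-nitrophenyl in place of 2-nitrophenyl on a double-bonded chain carbon bound to a double-bonded ring carbon gives a 63-fold higher number from compound 1 to compound 4 (1.80 log units; beyond the scatter), so this place on the shared core is highly sensitive to where the nitro group sits. The atoms stay the same, so the rearrangement alone carries a large step. Nothing at hand explains its size.

Open, going by these compounds, is whether a nitrile or an amine in place of the nitro group would keep the value of compound 1 or follow compound 4. Also open, on these data alone, is whether the same nitro shift gives a step of similar size on the core without the trimethoxyphenyl arm.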